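Aryl sulfonamide variation on the shared core: compound 3

The compounds below may be only part of what the source reports. "The series", "measured", "known", "first", "only" and "open" are said of these compounds alone.

Measured so far:
compound 1 `COc1cc2nc(N3CCN(S(=O)(=O)c4ccc(I)cc4)CC3)nc(N)c2cc1OC` gives 15000 nM
compound 2 `COc1cc2nc(N3CCN(S(=O)(=O)c4ccc(Cl)s4)CC3)nc(N)c2cc1OC` gives 25000 nM

Within the data shown here, in a functional assay on PC-3 cells (Homo sapiens) for inhibition (on this read-out higher numbers stand for weaker inhibition and lower numbers for stronger inhibition), compound 2 holds the highest of the two numbers known, with compound 1 the nearest, and the step of a 1.7-fold higher number from compound 1 to compound 2 (0.22 log units; within the scatter) stays within the scatter. Compound 3 `COc1cc2nc(N3CCN(S(=O)(=O)c4ccc(C)cc4)CC3)nc(N)c2cc1OC` differs from compound 2 by 4-methylphenyl in place of 5-chlorothiophen-2-yl on a sulfonyl sulfur. Among the measured compounds shown here, the only step that bears on this change is the swap of the aryl group on the sulfonyl sulfur from compound 1 to compound 2, which stayed within the scatter, so no step beyond the scatter is expected in this assay. Compound 3 is therefore estimated at 20000 nM (range 7000 nM to 55000 nM), the expected step of a 1.3-fold lower number from compound 2 to compound 3 (0.10 log units; within the scatter) being flat.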

Compound 3, half-maximal inhibitory concentration: 30000 nM
Estimate against measurement, compound 3: 1.5-fold (0.18 log units) below, and the stated range covers the measured number.
By their numbers in this assay, from the lowest: compounds 1, 2 and 3 (each within the scatter of the next).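

In this assay, the change from 5-chlorothiophen-2-yl to 4-methylphenyl on the sulfonyl sulfur gives a 1.2-fold higher number from compound 2 to compound 3 (0.08 log units; within the scatter) and so adds a third aryl group with no step beyond the scatter. Methyl in place of iodo on an aromatic carbon gives a 2.0-fold higher number from compound 1 to compound 3 (0.30 log units; within the scatter) as a result, which shows that this substituent swap on the phenyl group, not just the aryl exchange seen earlier, also leaves the read-out within the scatter. No supporting data bear on this result.

Still open, going by these compounds, is whether an amine or a carboxylic acid on the aryl group would move the number beyond the scatter. On these data alone, a longer alkyl chain in place of the aryl group on the sulfonyl sulfur is equally open.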